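A few compounds are considered here, and "the series" means these few. Any claim that something is new, unique, unknown or untested is made for them only; others in the source may bear on it.

Measured so far:
- compound 1 `CCN(CC)CCNC(=O)c1ccc(C(CC)(CC)c2ccc(OCC(O)C(C)(C)C)c(C)c2)n1CC`: 2310 nM
- compound 2 `CCN(CC)CCCNC(=O)c1ccc(C(CC)(CC)c2ccc(OCC(O)C(C)(C)C)c(C)c2)n1CC`: 1800 nM

In a functional assay on Caco-2 cells (Homo sapiens), read by MTT assay, with a stated time of 48 h (a lower number here means a stronger inhibitor, a higher number a weaker inhibitor), compound 2 gives 1800 nM. Among the compounds with values here, the only other number, from compound 1, lies within the scatter of it, so neither compound stands apart.

Compound 3 `C#CCNC(=O)c1ccc(C(CC)(CC)c2ccc(OCC(O)C(C)(C)C)c(C)c2)n1CC` changes the amide side chain of compound 2: ethynyl in place of 2-(diethylamino)ethyl on a saturated chain carbon bound to an amide-type nitrogen. Put another way, 3-(diethylamino)propyl gives way to propargyl.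

Within the data shown here, only one measured step bears on this, a 1.3-fold lower number from compound 1 to compound 2 (0.11 log units; within the scatter). That step keeps the diethylamino group, whereas compound 3 loses it, so it offers only a weak guide to size and none to direction. Among the measured compounds shown here, with no measured compound lacking that group, no shift beyond the scatter can be firmly expected. The expected step is a 1.4-fold higher number from compound 2 to compound 3 (0.14 log units; within the scatter), and this estimate is loose. For compound 3 the estimated value is 2500 nM, with an expected range from 700 nM to 10000 nM.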

Compound 3, half-maximal inhibitory concentration: 39100 nM
For compound 3 the middle estimate is 16-fold (1.19 log units) below the measured one, and the stated range ends below it.
By their numbers in this assay, from the lowest: compounds 2 and 1 (each within the scatter of the next); then compound 3.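

In this assay, the side chain on the amide nitrogen proves to matter: replacing 3-(diethylamino)propyl with propargyl gives a 22-fold higher number from compound 2 to compound 3 (1.34 log units; beyond the scatter), and the same replacement starting from the shorter diethylamino chain gives a 17-fold higher number from compound 1 to compound 3 (1.23 log units; beyond the scatter). Both steps are large, whereas the earlier change in chain length, a 1.3-fold lower number from compound 1 to compound 2 (0.11 log units; within the scatter), stayed within the scatter, so this position accepts that small change but not the loss of the whole diethylamino chain. No measurement shown here gives a reason for this loss.

The diethylamino group leaves and the triple bond enters in a single step, and the compounds shown do not tell which of the two matters. From the compounds shown here alone, how a plain propyl chain, or a chain ending in a smaller amine such as dimethylamino, would behave remains open.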